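The source may hold more compounds than are shown below. What is called first, only, known or untested is meant among the compounds shown, and "the series" means these compounds.

Of the compounds shown here, two have been measured so far. Compound 1 `COc1ccc(F)cc1Nc1cc(NC(=O)Nc2c(Cl)cccc2Cl)ncn1` gives 73.1% in a functional assay on NCI-H1581 cells (Homo sapiens) for inhibition, read by MTT assay, with a stated time of 48 h, tested at 10 uM; on this read-out higher numbers stand for more inhibition at the one concentration tested (going by the name of the read-out) and lower numbers for less inhibition. Compound 2 `COc1cc(NC(=O)Nc2cc(Nc3cc(F)ccc3OC)ncn2)cc(OC)c1` gives 42.1% in this assay. Among the compounds with values here, the single step between them, a number 31 percentage points lower from compound 1 to compound 2 (beyond the scatter), concerns the aryl on the amide-type nitrogen. Within the data shown here, on the numbers in hand, compound 2 stands lowest of the two, with compound 1 as its only and nearest neighbour, well beyond the scatter above it.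

Compound 3 `COc1cc(NC(=O)Nc2cc(Nc3cc(C)cc(F)c3)ncn2)cc(OC)c1` has not yet been measured. It differs from compound 2 in the following way: 3-fluoro-5-methylphenyl in place of 5-fluoro-2-methoxyphenyl on a nitrogen on an aromatic ring. Among the measured compounds shown here, the only measured step alters the aryl on the amide-type nitrogen and leaves the group on the aromatic-ring nitrogen untouched, so no measured step bears on the change now made. There is thus no direct guide to the size or direction of the step in this assay. Compound 3 is expected to stay close to compound 2, with a number 2.1 percentage points lower from compound 2 to compound 3 (within the scatter) taken as no change beyond the scatter, though with wide uncertainty. Compound 3 is estimated at 40%, in a range from 12% to 68%.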

Compound 3, a percentage reported as inhibition, at one concentration (the size of the read-out at that concentration, not a potency): 28.3%
Estimate against measurement, compound 3: 11.7 percentage points above; the measured number falls inside the stated range.
By their numbers in this assay, from the lowest: compound 3; then compound 2; then compound 1.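

In this assay, the group on a nitrogen on an aromatic ring also moves the read-out: 3-fluoro-5-methylphenyl in place of 5-fluoro-2-methoxyphenyl gives a number 13.8 percentage points lower from compound 2 to compound 3 (beyond the scatter), so the aryl on the amide-type nitrogen is no longer the only place shown to matter. This single step changes more than one feature at once, since the oxygen-bearing methoxy group leaves, a methyl group enters and the fluorine sits elsewhere on the ring, and the data cannot assign the drop to any one of these. No supporting measurement is available to explain the drop.

As far as these compounds go, it remains open whether the same change would have a similar effect with 2,6-dichlorophenyl on the amide-type nitrogen, and whether the methoxy group or the methyl group counts for more when each is varied alone. Also open, from the compounds shown here alone, is what a morpholine, a piperazine or a longer chain on the aryl at this nitrogen would give in this assay.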